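A few compounds are considered here, and "the series" means these few. Any claim that something is new, unique, unknown or untested is made for them only; others in the source may bear on it.

Measured so far in a functional assay on CHO cells for agonist activity at Alpha-1A adrenergic receptor (Homo sapiens), read by FLIPR and calcium flux; on this read-out higher numbers stand for an effect only at larger amounts of compound and lower numbers for an effect already at smaller amounts:

compound 1 `Cn1nccc1-c1cccc2c1CCC2c1ncc[nH]1` gives 278 nM
compound 2 `c1ccc2c(c1)CCCC2c1ncc[nH]1` gives 385 nM
compound 3 `Cc1ccc2c(c1NS(C)(=O)=O)CCC2c1ncc[nH]1` gives 33 nM

Compound 1 stands second highest of the three numbers. Its nearest neighbour is compound 2, whose value lies within the usual scatter of that of compound 1, so the two are not distinguished on this read-out. Compound 3 stands furthest away, with a lower number beyond the scatter; it is the only one of the three that carries a sulfonylamino group.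

Compound 4 `CCS(=O)(=O)Nc1cccc2c1CCC2c1ncc[nH]1` has not yet been measured in this assay. It differs from compound 1 in one place: (ethylsulfonyl)amino in place of 1-methyl-1H-pyrazol-5-yl on an aromatic carbon. For the measured compounds named here, no measured pair isolates this exact change, so only the bare values of compounds 1 and 3 are there to go on.

Given that compound 3, the one compound bearing a sulfonylamino group, gives 33 nM, a step towards lower numbers, beyond the scatter, is expected from compound 1 to compound 4, a 4.6-fold lower number from compound 1 to compound 4 (0.67 log units; beyond the scatter). Compound 4 is therefore estimated at 60 nM, with a range of 20 nM to 200 nM.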

Compound 4, half-maximal effective concentration: 32 nM
For compound 4 the middle estimate is 1.9-fold (0.27 log units) above the measured one; the measured number falls inside the stated range.
By their numbers in this assay, from the lowest: compounds 4 and 3 (each within the scatter of the next); then compounds 1 and 2 (each within the scatter of the next).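

In this assay, for the compounds shown here, the exchange of 1-methyl-1H-pyrazol-5-yl for (ethylsulfonyl)amino on this aromatic carbon gives an 8.7-fold lower number from compound 1 to compound 4 (0.94 log units; beyond the scatter) as the first one-place step, so the number at this position depends on the group it carries. The two groups have 6 heavy atoms each, so the step does not come with a change in heavy-atom count; it comes with the loss of the ring and a gain from 0 to 1 hydrogen-bond donor. No data here assign the step to any one of these differences.

Open, on these data alone, is whether a plain amine, an acetamide or a longer chain such as propylsulfonylamino at this carbon would give a similar number. Also open, as far as these compounds go, is whether methylation of the sulfonamide nitrogen would keep it.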